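Inverting one ring stereocentre in a cyclopropane carboxamide

This account rests on a few compounds, and the source may have more. Where it says the series, first, only, none or still open, it means among the compounds named here.

Compound 1 `COc1cc([C@H]2C[C@]2(CO)C(=O)Nc2ccccc2Cl)cc(OC)c1OC` was tested in a functional assay on A549 cells (Homo sapiens) for cytotoxicity, read by MTT assay, with a stated time of 48 h (a higher number here means a weaker inhibitor, a lower number a stronger inhibitor), and gave 36700 nM. Among the two numbers so far it is the lower; its nearest neighbour, compound 2 `CCOC(=O)[C@]1(C(=O)Nc2ccccc2Cl)C[C@@H]1c1cc(OC)c(OC)c(OC)c1`, gives 50900 nM in this assay, and the step of a 1.4-fold higher number from compound 1 to compound 2 (0.14 log units; within the scatter) falls within the scatter. Compound 3 `COc1cc([C@H]2C[C@@]2(CO)C(=O)Nc2ccccc2Cl)cc(OC)c1OC` is the next member to be measured in this assay. Against compound 1 the change is the two compounds have the same atoms and bonds and differ only in configuration as drawn: 1 of 2 stereo elements differ; a stereocentre at a saturated ring carbon is drawn S in compound 1 and R in compound 3. Among the measured compounds shown here, no measured step concerns a change of configuration: the only step recorded, from an ethoxycarbonyl to a hydroxymethyl group, is within the scatter and says nothing about how the two arrangements at the ring carbon compare. For the measured compounds named here, with that as the only guidance, the expected step of a 1.1-fold higher number from compound 1 to compound 3 (0.04 log units; within the scatter) for compound 3 is set near zero but with a wide allowance, since diastereomers can differ either way. Compound 3 is therefore estimated at 40000 nM in this assay, with a range from 10000 nM to 150000 nM.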

Compound 3, half-maximal inhibitory concentration: > 100000 nM
Compound 3: only a limit was reported; the forecaster's own chance of this, stated with the estimate: 20%; middle value at least 2.5-fold (0.39 log units) away from the limit.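

At this saturated ring carbon the configuration counts in this assay, which the earlier swap of hydroxymethyl for ethoxycarbonyl, a step within the scatter, could not show: changing the centre from S to R gives an at least 2.7-fold higher number from compound 1 to compound 3 (0.43 log units; beyond the scatter). For compound 3 the value > 100000 nM is a limit of the assay and not a number. The step can be put down to this one stereocentre alone, because nothing else separates the pair: the fact that compounds 1 and 3 differ only in the configuration as drawn.

On these data alone, how far compound 3 really lies from compound 1 stays open, because the reading stops at a limit: the limit of > 100000 nM in this assay, at which 1 of the 3 values shown sits. Also open, as far as these compounds go, is whether the same inversion carries the same penalty when a carboxylic acid or an amine, rather than hydroxymethyl, sits on that ring carbon.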